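The compounds below may be only part of what the source reports. "The series", "measured", "known", "first", "only" and "open" are said of these compounds alone.

Compound 1 `Oc1cccc(-c2cc(-c3ccc(F)cc3)cc(-c3cccc(O)c3)n2)c1` stands as the lower of the two numbers in hand: in a functional assay on DU-145 cells (Homo sapiens) for inhibition (a higher number here means a weaker inhibitor, a lower number a stronger inhibitor), compound 1 gives 7120 nM, while compound 2 `Oc1ccc(-c2cc(-c3ccc(F)cc3)cc(-c3cccc(O)c3)n2)cc1` gives 15200 nM in this assay. For the measured compounds named here, the only measured step, a 2.1-fold higher number from compound 1 to compound 2 (0.33 log units; beyond the scatter), concerns a 4-hydroxyphenyl in place of a 3-hydroxyphenyl and so does not touch the position changed here. Compound 3 `Oc1cccc(-c2cc(-c3ccccc3C(F)(F)F)cc(-c3cccc(O)c3)n2)c1` differs from compound 1 by 2-(trifluoromethyl)phenyl in place of 4-fluorophenyl on an aromatic carbon; 2-(trifluoromethyl)phenyl replaces 4-fluorophenyl opposite the ring nitrogen of the shared core. Going by the values given here, no measured pair shows what an exchange at this position does, so the step is expected to be small, with no direction that the data support, and most likely within the scatter; the estimated step is a 1.1-fold higher number from compound 1 to compound 3 (0.05 log units; within the scatter). Compound 3 is therefore expected to give about 8000 nM in this assay, within a range from 2500 nM to 25000 nM.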

Compound 3, half-maximal inhibitory concentration: 2870 nM
Compound 3: the middle estimate sits 2.8-fold (0.45 log units) above what was measured; measured number inside the range.
By their numbers in this assay, from the lowest: compound 3; then compound 1; then compound 2.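

The position opposite the ring nitrogen of the shared core now proves able to move the number in this assay as 2-(trifluoromethyl)phenyl in place of 4-fluorophenyl gives a 2.5-fold lower number from compound 1 to compound 3 (0.39 log units; beyond the scatter) and so a stronger inhibitor, even though the entering group has 10 heavy atoms against 7 for the group that leaves. This exchange alters both the substituent on the phenyl ring and where it sits, and this single pair cannot separate the two changes. Nothing measured here accounts for the step.

The compounds shown leave open whether 2-fluorophenyl, 4-(trifluoromethyl)phenyl or unsubstituted phenyl at this position would tell those two changes apart. They also leave open how an amine, a carboxylic acid or a short alkyl chain would read here in this assay as a replacement for the aryl group.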